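The source may report more compounds than this note shows. Statements on the series, on what has been measured and on what is new or still open speak of the compounds shown alone.

Of the compounds shown here, three sharing one core have been measured in an ADME assay on MDCKII-LE cells (Canis lupus familiaris) for permeability; on this read-out lower numbers stand for lower permeability and higher numbers for higher permeability: compound 1 `N#CCCCCN([C@H](CCC(F)(F)F)C(N)=O)S(=O)(=O)c1ccc(Cl)cc1` gives 24 10^-6 cm/s, compound 2 `N#C[C@@H]1C[C@H]1CN([C@H](CCC(F)(F)F)C(N)=O)S(=O)(=O)c1ccc(Cl)cc1` gives 9.94 10^-6 cm/s, and compound 3 `C[C@]1(C#N)C[C@H](CN([C@H](CCC(F)(F)F)C(N)=O)S(=O)(=O)c2ccc(Cl)cc2)C1` gives 21.8 10^-6 cm/s. Compound 3 thus sits level with compound 1, and both stand above compound 2.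

The next compound, compound 4 `N#CC1(CN([C@H](CCC(F)(F)F)C(N)=O)S(=O)(=O)c2ccc(Cl)cc2)CC1`, has not yet been measured. It differs from compound 3 by a single change, 1-cyanocyclopropyl in place of 3-cyano-3-methylcyclobutyl on a saturated chain carbon bound to a sulfonamide nitrogen.

The closest guide is a 2.2-fold higher number from compound 2 to compound 3 (0.34 log units; beyond the scatter), which has the same 3-cyano-3-methylcyclobutyl group at the higher number and a cyclopropyl group at the lower one. Likewise, a 2.4-fold lower number from compound 1 to compound 2 (0.38 log units; beyond the scatter) ends on the cyclopropyl group at the lower number, whereas a 1.1-fold lower number from compound 1 to compound 3 (0.04 log units; within the scatter) stays within the scatter. Among the measured compounds shown here, this evidence is thin, since compound 2 is the only measured cyclopropyl compound, and it carries 2-cyanocyclopropyl rather than 1-cyanocyclopropyl.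

A lower number is therefore expected in this assay, by a somewhat smaller margin than the closest guide shows. The expected step is a 1.8-fold lower number from compound 3 to compound 4 (0.26 log units; within the scatter). Compound 4 is estimated at 12 10^-6 cm/s, with an expected range from 7 10^-6 cm/s to 23 10^-6 cm/s.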

Compound 4, apparent permeability: 29.9 10^-6 cm/s
Compound 4: the middle estimate sits 2.5-fold (0.40 log units) below what was measured, and the stated range ends below it.
By their numbers in this assay, from the lowest: compound 2; then compounds 3, 1 and 4 (each within the scatter of the next).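

In this assay, a three-membered ring at this place, on a saturated chain carbon bound to a sulfonamide nitrogen, does not by itself go with the low number that compound 2 had suggested: the step of a 3.0-fold higher number from compound 2 to compound 4 (0.48 log units; beyond the scatter) separates two groups that differ only in where the nitrile stands on the cyclopropyl ring. The steps of a 1.4-fold higher number from compound 3 to compound 4 (0.14 log units; within the scatter) and a 1.2-fold higher number from compound 1 to compound 4 (0.10 log units; within the scatter) put 1-cyanocyclopropyl level with both 3-cyano-3-methylcyclobutyl and 3-cyanopropyl, so among these four compounds only compound 2, with 2-cyanocyclopropyl, stands apart, beyond the scatter from each of the others. Nothing available accounts for the gap between the two cyanocyclopropyl groups.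

The compounds shown therefore leave open whether the lower number of compound 2 is particular to 2-cyanocyclopropyl or would recur with other groups that carry the nitrile elsewhere on a ring, such as 2-cyanocyclobutyl. They also leave open how the read-out would respond at this place to a group that carries a primary amine or a carboxylic acid in place of the nitrile.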